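Working notes: methoxy in place of hydrogen on compound 3

This account rests on a few compounds, and the source may have more. Where it says the series, first, only, none or still open, it means among the compounds named here.

compound 1 `COc1cc(/C=C/C(=O)/C=C/c2nc(C)c(C)nc2C)ccc1O` 2190 nM
compound 2 `COc1cccc(/C=C/C(=O)/C=C/c2nc(C)c(C)nc2C)c1` 3300 nM
compound 3 `COc1ccc(/C=C/C(=O)/C=C/c2nc(C)c(C)nc2C)cc1` 3500 nM

In a functional assay on A549 cells (Homo sapiens) for antiproliferative activity, read by MTT assay, with a stated time of 72 h (a lower number here means a stronger inhibitor, a higher number a weaker inhibitor), compound 3 gives 3500 nM, a value within the scatter of those of the other two compounds. Compound 4 `COc1ccc(/C=C/C(=O)/C=C/c2nc(C)c(C)nc2C)cc1OC` differs from compound 3 by methoxy in place of hydrogen on an aromatic carbon, ortho to a methoxy group. Among the measured compounds shown here, the only measured step, a 1.5-fold higher number from compound 1 to compound 2 (0.18 log units; within the scatter), puts hydrogen in place of hydroxy on an aromatic carbon and lies within the scatter. For the measured compounds named here, no measured step introduces methoxy, so this evidence is indirect. No shift beyond the scatter is expected in this assay, and the expected change is a 1.2-fold lower number from compound 3 to compound 4 (0.07 log units; within the scatter). The estimated value for compound 4 is 3000 nM, with an expected range of 1500 nM to 6000 nM.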

Compound 4, half-maximal inhibitory concentration: 3790 nM
For compound 4 the middle estimate is 1.3-fold (0.10 log units) below the measured one; the range from low to high includes it.
By their numbers in this assay, from the lowest: compounds 1, 2, 3 and 4 (each within the scatter of the next).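

In this assay, methoxy in place of hydrogen, ortho to a methoxy group, now has a direct reading from either compound with a single methoxy group: a 1.1-fold higher number from compound 3 to compound 4 (0.03 log units; within the scatter), and a 1.1-fold higher number from compound 2 to compound 4 (0.06 log units; within the scatter). Methyl in place of hydrogen on an oxygen on an aromatic ring, a change no earlier pair carried, gives a 1.7-fold higher number from compound 1 to compound 4 (0.24 log units; within the scatter). No measurement on hand offers an explanation for these steps.

Going by these compounds, whether an amine or a carboxylic acid at this position would give a step beyond the scatter stays open. On these data alone, the effect of a longer chain on the oxygen also stays open.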